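The source may hold more compounds than are shown below. What is called first, only, known or untested is meant among the compounds shown, and "the series" means these compounds.

Compound 3 `CN1CCCN(Cc2ccc(-c3ccc(CN4CCCN(C)CC4)cc3C#N)cc2)CC1` gives 10 nM in an assay on isolated protein for binding affinity to choline kinase alpha (Homo sapiens), read by surface plasmon resonance (a higher number here means weaker binding, a lower number tighter binding), the lowest number among the three compounds measured. Compound 1 `CN1CCCN(Cc2ccc(-c3ccc(N4CCN(C)CC4)cc3)cc2)CC1` gives 769 nM in this assay, and compound 2 `COC(=O)c1ccc(-c2ccc(CN3CCCN(C)CC3)cc2)cc1` gives 2400 nM. Among the compounds with values here, the one change measured so far, a 3.1-fold higher number from compound 1 to compound 2 (0.49 log units; beyond the scatter), concerns a different part of the molecule than the step now followed. Compound 4 `CN1CCCN(Cc2ccc(-c3ccc(CN4CCCN(C)CC4)cc3)cc2)CC1` differs from compound 3 only by hydrogen in place of cyano on an aromatic carbon; the change leaves a cyano group of two heavy atoms, one carbon and one nitrogen, with one triple bond outside aromatic rings and one hydrogen-bond acceptor, and puts a hydrogen atom in its place, on an aromatic carbon of a six-membered aromatic ring of carbon only, ortho to a large group and meta to a (4-methyl-1,4-diazepan-1-yl)methyl group of nine heavy atoms. Within the data shown here, no measured step shows what removing a cyano group does here. Compound 4 is therefore expected to stay near compound 3, with a step of a 2.0-fold higher number from compound 3 to compound 4 (0.30 log units; within the scatter) that may fall within the scatter. The estimate for compound 4 in this assay is 20 nM, between 6 nM and 70 nM.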

Compound 4, dissociation constant: 382 nM
Compound 4: the middle estimate sits 19-fold (1.28 log units) below what was measured; measured number outside the range, above it.
By their numbers in this assay, from the lowest: compound 3; then compounds 4 and 1 (each within the scatter of the next); then compound 2.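

In this assay, the tight binding of compound 3 depends heavily on the nitrile on this aromatic carbon: putting hydrogen in its place gives a 38-fold higher number from compound 3 to compound 4 (1.58 log units; beyond the scatter), a far larger step than any seen earlier. With hydrogen at this position, changes elsewhere count for much less: (4-methyl-1,4-diazepan-1-yl)methyl in place of methoxycarbonyl gives a 6.3-fold lower number from compound 2 to compound 4 (0.80 log units; beyond the scatter), while the same group in place of 4-methylpiperazin-1-yl gives a 2.0-fold lower number from compound 1 to compound 4 (0.30 log units; within the scatter), a step within the scatter. No measurement here explains why the nitrile matters so much.

From the compounds shown here alone, it remains open whether the nitrile is special or whether a chlorine atom, a methyl group or a primary amide on this carbon would also give tight binding. Also open, going by these compounds, is how a nitrile would behave on another carbon of this ring.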